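Trading a Branched Acid Chain for a Straight One

The source may report more compounds than this note shows. Statements on the series, on what has been measured and on what is new or still open speak of the compounds shown alone.

Of the compounds shown here, three built on one shared core have been measured in a physicochemical assay for lipophilicity, read by HPLC, at pH 7.4; a lower number here means a more polar compound, a higher number a more lipophilic compound. Compound 1 `O=C(O)COc1c(Cl)cc([C@H]2CC[C@]3(CC2)OOC2(O3)C3CC4CC(C3)CC2C4)cc1Cl` gives 3.3. Compound 2 `CC(=O)NC1C2CC3CC1CC(C2)C31OO[C@]2(CC[C@@H](c3ccc(OCC(=O)O)cc3)CC2)O1` gives 1.8. Compound 3 `CC(C)(Oc1ccc([C@H]2CC[C@]3(CC2)OOC2(O3)C3CC4CC(C3)CC2C4)cc1)C(=O)O` gives 3.1, which places it second highest of the three numbers: compound 1 sits only slightly above it, a gap that falls within the scatter of repeated measurements, while compound 2 sits well below it, a gap that lies beyond that scatter. Compound 3 and compound 1 therefore cannot be told apart on these numbers, whereas compound 2 is clearly the more polar of the set.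

Compound 4 `O=C(O)CCCCOc1ccc([C@H]2CC[C@]3(CC2)OOC2(O3)C3CC4CC(C3)CC2C4)cc1` has not yet been measured in this assay . It differs from compound 3 in a single spot: 4-carboxybutyl in place of 1-carboxy-1-methylethyl on an oxygen on an aromatic ring. Among the compounds with values here, no pair of measured compounds shows this kind of change, so there is no measured step to lean on. Going by the larger count of carbon atoms in the group that enters, a modest upward step is expected, one that may just clear the scatter: the expected step from compound 3 to compound 4 is a number 0.40 log units higher from compound 3 to compound 4 (beyond the scatter). Compound 4 is therefore estimated at 3.5, with a likely range from 3 to 4.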

Compound 4, distribution coefficient: 4
Beside the measured number, compound 4's estimate is 0.50 log units below it; the measured number falls inside the stated range.
By their numbers in this assay, from the lowest: compound 2; then compounds 3 and 1 (each within the scatter of the next); then compound 4.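

Within the data shown here, on an oxygen on an aromatic ring, putting 4-carboxybutyl in place of 1-carboxy-1-methylethyl gives a reading in this assay that moves clearly upward, a number 0.90 log units higher from compound 3 to compound 4 (beyond the scatter), and this is the first single-place step in the set. It shows that this position responds to a change in the chain even though the carboxylic acid stays and the hydrogen-bond donor and acceptor counts of the two groups match. What differs is the chain itself, branched with 4 carbon in the group that leaves and straight with 5 carbon in the group that enters, and no data here bear on what drives the step.

The step combines the loss of branching with the change in carbon count, and a straight 3-carboxypropyl chain on the same oxygen would help pull those two apart. Also open, from the compounds shown here alone, is how the number would respond to a longer chain, or to an amine or a primary amide at the chain end in place of the carboxylic acid.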